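Thioamide nitrogen substitution, one step in the series

The source may hold more compounds than are shown below. What is called first, only, known or untested is meant among the compounds shown, and "the series" means these compounds.

Measured so far:
compound 1 `N=C(S)CCCCCn1nc(-c2ccccc2)ccc1=O` — 91.4%
compound 2 `C/N=C(/S)CCCCCn1nc(-c2ccccc2)ccc1=O` — 92.3%

In a functional assay on the whole organism (stomach) for inhibition, with Rattus norvegicus as the target, at a dose of 100 mg/kg by the intraduodenal route (a higher number here means more inhibition at the dose given (going by the name of the read-out), a lower number less inhibition), compound 2 gives 92.3% and compound 1 gives 91.4%; compound 2 stands highest of the two numbers, but the step of a number 0.9 percentage points higher from compound 1 to compound 2 (within the scatter) lies within the scatter, so no order between them is claimed. Compound 3 `CN(C)C(=S)CCCCCn1nc(-c2ccccc2)ccc1=O` is not yet measured; it differs from compound 2 as follows: a group of 5 heavy atoms (3 carbon, 1 nitrogen, 1 sulfur; no ring) in place of a group of 4 heavy atoms (2 carbon, 1 nitrogen, 1 sulfur; no ring), on a saturated chain carbon, five bonds along the chain from an aromatic nitrogen. Among the compounds with values here, the only measured step that bears on this place is a number 0.9 percentage points higher from compound 1 to compound 2 (within the scatter), which was within the scatter. A step within the scatter, a number 4.3 percentage points lower from compound 2 to compound 3 (within the scatter), is therefore expected. For compound 3 the expected value is 88%, with a range from 72% to 97%.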

Compound 3, a percentage reported as inhibition, in the whole organism at one dose (the size of the read-out at that dose, not a potency): 58.2%
Compound 3: middle estimate off by 29.8 percentage points, on the high side; the measured number lies below the stated range.
By their numbers in this assay, from the lowest: compound 3; then compounds 1 and 2 (each within the scatter of the next).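

In this assay, the thioamide nitrogen on the saturated chain carbon, five bonds along the chain from an aromatic nitrogen, is not indifferent to substitution: the read-out shows a number 34.1 percentage points lower from compound 2 to compound 3 (beyond the scatter) and a number 33.2 percentage points lower from compound 1 to compound 3 (beyond the scatter). The group that enters has 0 hydrogen-bond donors, whereas the group of 4 heavy atoms that leaves has 1 hydrogen-bond donor. No measurement at hand accounts for the drop.

On these data alone, whether heavy-atom count or donor count tracks the drop remains open. A single ethyl group on that nitrogen, or a piperidine ring in its place, would bear on this.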